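Bromo for tert-butyl on a benzimidazole-bearing pyrazolone

The compounds below may be only part of what the source reports. "The series", "measured", "known", "first", "only" and "open" are said of these compounds alone.

Measured so far:
compound 1 `Cc1[nH]n(-c2nc3ccccc3n2C)c(=O)c1C` — > 10000 nM
compound 2 `Cc1[nH]n(-c2nc3cc(C(C)(C)C)ccc3[nH]2)c(=O)c1Cc1ccccc1` — 640 nM
compound 3 `Cc1nn(-c2nc3ccccc3[nH]2)c(O)c1Cc1ccccc1` — 480 nM

In an assay on isolated protein for inhibition of alpha-ketoglutarate-dependent dioxygenase alkB homolog 3 (Homo sapiens), read by polymerase chain reaction, with a stated time of 1 h (on this read-out higher numbers stand for weaker inhibition and lower numbers for stronger inhibition), compound 2 gives 640 nM, the highest of the two numbers returned. Compound 3 gives 480 nM, which lies within the scatter of compound 2. Compound 1 gives only a limit, > 10000 nM, at which one of the three values sits (the limit of > 10000 nM in this assay, at which 1 of the 3 values shown sits).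

Compound 4 `Cc1[nH]n(-c2nc3cc(Br)ccc3[nH]2)c(=O)c1Cc1ccccc1` differs from compound 2 in one place: bromo in place of tert-butyl on an aromatic carbon. Among the measured compounds shown here, no measured pair shows this change, so no step beyond the scatter is expected in this assay , in either direction. Compound 4 is therefore estimated at 700 nM, between 250 nM and 2500 nM, a step of a 1.1-fold higher number from compound 2 to compound 4 (0.04 log units; within the scatter).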

Compound 4, half-maximal inhibitory concentration: 490 nM
Compound 4: middle estimate off by 1.4-fold (0.15 log units), on the high side; the measured number falls inside the stated range.
By their numbers in this assay, from the lowest: compounds 3, 4 and 2 (each within the scatter of the next). At a limit, above all of these: compound 1.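

In this assay, bromo in place of tert-butyl on this aromatic carbon gives a 1.3-fold lower number from compound 2 to compound 4 (0.12 log units; within the scatter), so the position accepts either group without a change beyond the scatter. Among the compounds shown here, the earlier compounds held no pair differing at this position alone, so this is the first direct reading of it. Nothing shown gives a reason for this outcome. As far as these compounds go, whether an amine, a carboxylic acid or a longer chain on this aromatic carbon would keep the number in the same range remains open. So does whether the same exchange would behave alike on a different core.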